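Rearranging a hexyl chain at the edge of measurement

The compounds below may be only part of what the source reports. "The series", "measured", "known", "first", "only" and "open" are said of these compounds alone.

Measured so far:
compound 1 `COc1cccc(OCCC(C)(C)C)c1C(=O)/C=C/c1ccc(O)cc1`: > 30000 nM
compound 2 `CCCCCCOc1cccc(O)c1C(=O)/C=C/c1ccc(O)cc1`: > 30000 nM

Of the compounds shown here, two have been tested in a functional assay on ACHN cells (Homo sapiens) for antiproliferative activity, read by sulforhodamine B assay; on this read-out lower numbers stand for stronger inhibition of growth and higher numbers for weaker inhibition of growth. Compound 1 gives > 30000 nM, which is a limit and not a number. Compound 2 gives > 30000 nM, which is likewise a limit and not a number. Both results therefore sit at one point, (the limit of > 30000 nM in this assay, at which 2 of the 2 values shown sit).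

Compound 3 `CC(C)(C)CCOc1cccc(O)c1C(=O)/C=C/c1ccc(O)cc1` has not yet been measured. It has the same atoms as compound 2, joined differently: tert-butyl in place of butyl on a saturated chain carbon, two bonds along the chain from an oxygen on an aromatic ring. The hexyloxy of compound 2 thus gives way to 3,3-dimethylbutoxy.

Within the data shown here, no measured pair in this small series shows what such a change does. The expectation in this assay is therefore for no step beyond the usual scatter, and no direction can be favoured. It rests on compound 2, whose > 30000 nM is a limit. The expected size of the change is estimated as a number no higher from compound 2 to compound 3 (the limit leaves the size open). Compound 3 may well return only a limit too. For compound 3 the estimated value is 30000 nM, with an expected range from 10000 nM to 40000 nM.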

Compound 3, concentration for 50% growth inhibition: 3140 nM
Compound 3: the middle estimate sits 9.6-fold (0.98 log units) above what was measured; the whole stated range lies above it.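

In this assay, among these compounds, hexyloxy giving way to 3,3-dimethylbutoxy, the same atoms joined differently, produces the first step that can be read: an at least 9.5-fold lower number from compound 2 to compound 3 (0.98 log units; beyond the scatter). Among the compounds shown here, with the 3,3-dimethylbutoxy chain held constant, hydrogen in place of methyl on an oxygen on an aromatic ring gives an at least 9.5-fold lower number from compound 1 to compound 3 (0.98 log units; beyond the scatter), so among the three compounds only the one that pairs this branched chain with that hydrogen comes off the limit. Each of these steps is open on one side, and its true size could be larger than printed: the limit of > 30000 nM in this assay, at which 2 of the 3 values shown sit.

What the compounds shown leave open is how far compound 1 and compound 2 lie beyond that limit, and so whether the branched chain or the hydrogen on the oxygen counts for more. They also do not tell whether the effect is particular to tert-butyl at this place on the chain, or whether a cyclohexyl group, a longer branched chain or a chain ending in an amine would give a similar value in this assay.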